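Benzothiophene in place of indole on the side chain

The source may report more compounds than this note shows. Statements on the series, on what has been measured and on what is new or still open speak of the compounds shown alone.

The set is measured in an in vitro functional assay on RBL cells for antagonist activity at C-C chemokine receptor type 8 (Homo sapiens), read by FLIPR and calcium flux; on this read-out higher numbers stand for weaker inhibition and lower numbers for stronger inhibition. Compound 1 `COc1ccc2nccc(C3CN(C4CCN(Cc5cc6ccccc6[nH]5)CC4)C(=O)O3)c2n1` gives 31.6 nM in this assay. Compound 2 `O=C1OC(c2cccc3ccccc23)CN1C1CCN(Cc2cc3ccccc3[nH]2)CC1` reaches only a limit of the assay, < 50200 nM, and no number. Compound 3 `COc1ccc2nccc(C3CN(C4CCN(Cc5c[nH]c6ccccc56)CC4)C(=O)O3)c2c1` likewise gives only a limit in this assay, < 50200 nM. Compound 3 therefore stands with compound 2 at the limit of < 50200 nM in this assay, at which 2 of the 3 values shown sit, and only compound 1 has a measured number; nothing beyond that is known for the pair of compound 1 and compound 3, which differ in more than one place.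

Compound 4 `COc1ccc2nccc(C3CN(C4CCN(Cc5cc6ccccc6s5)CC4)C(=O)O3)c2c1` has not been measured. It differs from compound 3 by 1-benzothiophen-2-yl in place of 1H-indol-3-yl on a saturated chain carbon bound to an amine nitrogen in a ring. Going by the values given here, no step between measured compounds covers this change, so the size of the step is open; the account expects a move toward stronger inhibition in this assay, beyond the usual scatter, with a broad uncertainty. Compound 4 is thus estimated at 200 nM in this assay, between 20 nM and 5000 nM, an expected step that the limit leaves unreadable from compound 3 to compound 4.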

Compound 4, half-maximal inhibitory concentration: 794 nM
For compound 4 the middle estimate is 4.0-fold (0.60 log units) below the measured one; the measured number falls inside the stated range.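

No step can be read from compound 3 to compound 4 in this assay, because compound 3 gives only a limit and no number: the limit of < 50200 nM in this assay, at which 2 of the 4 values shown sit. The compounds shown leave open how large a change in inhibition comes with 1-benzothiophen-2-yl in place of 1H-indol-3-yl.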